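This account rests on a few compounds, and the source may have more. Where it says the series, first, only, none or still open, it means among the compounds named here.

Compound 1 `CCCCc1ccc(-n2cc(-c3cn([C@H]4C[C@H](O)[C@@H](CO)O4)c(=O)[nH]c3=O)nn2)cc1` and compound 2 `O=c1[nH]c(=O)n([C@H]2C[C@H](O)[C@@H](CO)O2)cc1-c1cn(-c2ccc(OC(F)(F)F)cc2)nn1` share one core and differ only in the group on the aromatic carbon, butyl in compound 1 and trifluoromethoxy in compound 2. In an ADME assay on HEL cells (Homo sapiens) for cytotoxicity, read by cell counting, with a stated time of 3 days (a lower number here means that less compound is tolerated, a higher number that more compound is tolerated), compound 1 gives 230000 nM. For compound 2 this assay returns only a limit, > 220000 nM, so compound 2 stands at the edge of the measured range rather than at a number. The step that the limit leaves unreadable from compound 1 to compound 2 therefore cannot be read, since one of its two values is the limit (the limit of > 220000 nM in this assay, at which 1 of the 2 values shown sits). Compound 3 `O=c1[nH]c(=O)n([C@H]2C[C@H](O)[C@@H](CO)O2)cc1-c1cn(-c2ccc(Oc3ccccc3)cc2)nn1` carries the change (phenyl in place of trifluoromethyl on an oxygen on an aromatic ring). For the measured compounds named here, the only measured step that touches this part of the molecule is the unreadable one, so no size can be taken from it for this assay; what can be said is that both measured compounds sit near the top of the range, and a step beyond the scatter in either direction is not foreseen. Compound 3 is therefore expected to give about 200000 nM, between 60000 nM and 300000 nM, which amounts to an estimated step of an at least 1.1-fold lower number from compound 2 to compound 3 (0.04 log units; that floor lies within the scatter).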

Compound 3, minimum cytotoxic concentration: 130000 nM
Compound 3: middle estimate off by 1.5-fold (0.19 log units), on the high side, within the range that was stated.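

Replacing trifluoromethyl with phenyl on the oxygen gives, in this assay, an at least 1.6-fold lower number from compound 2 to compound 3 (0.22 log units; that floor lies within the scatter), and only a floor can be read, since compound 2 stands at a limit: the limit of > 220000 nM in this assay, at which 1 of the 3 values shown sits.

Unlike the exchange of butyl for trifluoromethoxy, the exchange of butyl for phenoxy on the aromatic carbon can be read as a step: a 1.8-fold lower number from compound 1 to compound 3 (0.25 log units; within the scatter). Phenoxy and butyl at this place therefore cannot be told apart in this assay, and no readable step shown here lies beyond the scatter.

The compounds shown leave open how far past its limit compound 2 lies, and so whether phenyl in place of trifluoromethyl on the oxygen amounts to a step beyond the scatter. They also leave open whether a group of another kind on the aromatic carbon, such as an amine, a carboxylic acid or a longer chain than butyl, would move the number in this assay by more than the scatter.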